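A Side-Chain Swap Under a Cytotoxicity Limit

A few compounds are considered here, and "the series" means these few. Any claim that something is new, unique, unknown or untested is made for them only; others in the source may bear on it.

In an ADME assay on Huh-7 cells (Homo sapiens) for cytotoxicity, with a stated time of 72 h (on this read-out higher numbers stand for lower toxicity in this test and lower numbers for higher toxicity in this test), compound 1 `CC(C)(C)Cn1nc(-c2cccs2)c(O)c(C2=NS(=O)(=O)c3cc(NS(C)(=O)=O)ccc3N2)c1=O` gives > 1000 nM, which is a limit of the test and not a number. On these data alone, compound 2 `CS(=O)(=O)Nc1ccc2c(c1)S(=O)(=O)N=C(c1c(O)c(-c3cccs3)nn(CC3(C(F)(F)F)CC3)c1=O)N2` gives > 1000 nM, which is also a limit, so its true position is unknown. Both compounds share the same ceiling: the limit of > 1000 nM in this assay, at which 2 of the 2 values shown sit. Compound 3 `CS(=O)(=O)Nc1ccc2c(c1)S(=O)(=O)N=C(c1c(O)c(-c3cccs3)nn(CCC3CCCC3)c1=O)N2` puts cyclopentylmethyl in place of 1-(trifluoromethyl)cyclopropyl on a saturated chain carbon bound to an aromatic nitrogen. Going by the values given here, the only measured step that bears on this change is a step that the two limits leave unreadable from compound 1 to compound 2. Because a step that the two limits leave unreadable from compound 1 to compound 2 has no readable size, it offers no size or direction to carry over, and no shift beyond the scatter is expected in this assay. The expected change is a step that the limit leaves unreadable from compound 2 to compound 3. For compound 3 the estimate is 2000 nM, with an expected range of 1000 nM to 10000 nM.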

Compound 3, half-maximal cytotoxic concentration: > 1000 nM
Compound 3: no number, only a limit (the forecaster's own chance of this, stated with the estimate: 85%); the middle value lies beyond the limit too.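

In this assay compound 3 gives > 1000 nM, which is a limit and not a number. Going by these compounds alone, compound 1 and compound 2 also stop at a limit, so no step among the three can be read. How far apart the three truly lie stays open, because all share one ceiling: the limit of > 1000 nM in this assay, at which 3 of the 3 values shown sit.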